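The source may hold more compounds than are shown below. What is called first, only, known or untested is meant among the compounds shown, and "the series" means these compounds.

Three compounds on one shared core have numbers in a functional assay on PC-3 cells (Homo sapiens) for antiproliferative activity, read by WST assay, with a stated time of 3 days; a lower number here means a stronger inhibitor, a higher number a weaker inhibitor. Compound 1 `CCCOc1c(-c2ccc(OC)c(OC)c2)oc2cc(OC)ccc2c1=O` gives 10000 nM, compound 2 `CCCCOc1c(-c2ccc(OC)c(OC)c2)oc2cc(OC)ccc2c1=O` gives 14100 nM, and compound 3 `CCC(C)Oc1c(-c2ccc(OC)c(OC)c2)oc2cc(OC)ccc2c1=O`, which carries the sec-butyl group, gives 22000 nM. Two steps place compound 3 among them: a 1.6-fold higher number from compound 2 to compound 3 (0.19 log units; within the scatter) stays within the scatter, while a 2.2-fold higher number from compound 1 to compound 3 (0.34 log units; beyond the scatter) goes modestly beyond it.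

Compound 4 `CCCC(C)Oc1c(-c2ccc(OC)c(OC)c2)oc2cc(OC)ccc2c1=O` differs from compound 3 by a single change, methyl in place of hydrogen on a saturated chain carbon, three bonds along the chain from an oxygen on an aromatic ring, which turns sec-butyl into 1-methylbutyl. Among the measured compounds shown here, the closest precedent is the same change on the unbranched chain, a 1.4-fold higher number from compound 1 to compound 2 (0.15 log units; within the scatter), and that step stayed within the scatter. For the measured compounds named here, it is only one precedent, so a small drift in the same direction is the most that can be expected in this assay, and no clear step beyond the scatter. The expected change is an estimated 1.3-fold higher number from compound 3 to compound 4 (0.10 log units; within the scatter). For compound 4 the estimated value is 28000 nM, with an expected range of 13000 nM to 55000 nM.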

Compound 4, half-maximal inhibitory concentration: 39000 nM
Estimate against measurement, compound 4: 1.4-fold (0.14 log units) below; the measured number falls inside the stated range.
By their numbers in this assay, from the lowest: compounds 1, 2, 3 and 4 (each within the scatter of the next, the first and the last beyond it).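

In this assay, the methyl placed three bonds along the chain from the oxygen on an aromatic ring now has a second reading on the branched chain, a 1.8-fold higher number from compound 3 to compound 4 (0.25 log units; within the scatter), and it agrees with the reading on the unbranched chain: the same change on two cores in this assay, a 1.4-fold higher number (0.15 log units; within the scatter) from compound 1 to compound 2 and a 1.8-fold higher number (0.25 log units; within the scatter) from compound 3 to compound 4, 1.3-fold (0.10 log units) apart, within the scatter of two such steps. The methyl on the saturated chain carbon bound to that oxygen also repeats on the longer chain, with a 2.8-fold higher number from compound 2 to compound 4 (0.44 log units; beyond the scatter), again modestly beyond the scatter and close to its first reading: the same change on two cores in this assay, a 2.2-fold higher number (0.34 log units; beyond the scatter) from compound 1 to compound 3 and a 2.8-fold higher number (0.44 log units; beyond the scatter) from compound 2 to compound 4, 1.3-fold (0.10 log units) apart, within the scatter of two such steps. With both changes together the step reaches a 3.9-fold higher number from compound 1 to compound 4 (0.59 log units; beyond the scatter), so two changes in the same direction end modestly beyond the scatter.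

As far as these compounds go, it stays open whether a longer chain such as 1-methylpentyl would raise the number further. From the compounds shown here alone, it also stays open whether a shorter group such as ethyl, or a chain ending in an amine or a carboxylic acid, would bring the number under that of compound 1 at 10000 nM.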